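Thienyl for dimethylphenyl carried onto a second core

The source may report more compounds than this note shows. Statements on the series, on what has been measured and on what is new or still open speak of the compounds shown alone.

Compound 2 `Cc1ccc(S(=O)(=O)/C(=C/c2cc(C)ccc2C)C(=O)c2ccc(Cl)cc2)cc1` and compound 1 `Cc1ccc(S(=O)(=O)/C(=C/c2sccc2C)C(=O)c2ccc(Cl)cc2)cc1` share one core. In a functional assay on DU-145 cells (Homo sapiens) for inhibition, read by trypan blue exclusion, with a stated time of 96 h (a higher number here means a weaker inhibitor of growth, a lower number a stronger inhibitor of growth), compound 2 gives 1000 nM, while compound 1 gives 10000 nM. The change between them, (3-methylthiophen-2-yl in place of 2,5-dimethylphenyl on a double-bonded chain carbon bound to a double-bonded chain carbon), made the step of a 10-fold higher number from compound 2 to compound 1 (1.00 log units; beyond the scatter). Compound 3 `Cc1ccc(C)c(/C=C(/SCc2ccc(F)cc2)C(=O)c2ccc(Br)cc2)c1` rests on a different core; the difference between the two cores is not broken down here. In this assay compound 3 gives 1000 nM, level with compound 2 at the digits shown. Compound 4 `Cc1ccsc1/C=C(/SCc1ccc(F)cc1)C(=O)c1ccc(Br)cc1` is unmeasured and differs from compound 3 by 3-methylthiophen-2-yl in place of 2,5-dimethylphenyl on a double-bonded chain carbon bound to a double-bonded chain carbon, the same change as from compound 2 to compound 1, at the same place. Because the step of a 10-fold higher number from compound 2 to compound 1 (1.00 log units; beyond the scatter) came from this change on the other core, a step of similar size is expected for compound 4, a 10-fold higher number from compound 3 to compound 4 (1.00 log units; beyond the scatter). Within the data shown here, the single precedent leaves the carry-over to the core of compound 3 uncertain. Compound 4 is therefore expected near 10000 nM, estimated between 3000 nM and 30000 nM.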

Compound 4, concentration for 50% growth inhibition: 50000 nM
For compound 4 the middle estimate is 5.0-fold (0.70 log units) below the measured one; measured number outside the range, above it.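

In this assay, 3-methylthiophen-2-yl in place of 2,5-dimethylphenyl gives a higher number on both cores, here with a 50-fold higher number from compound 3 to compound 4 (1.70 log units; beyond the scatter). The direction of the change carries from one core to the other, but its size does not: the same change on two cores in this assay, a 10-fold higher number (1.00 log units; beyond the scatter) from compound 2 to compound 1 and a 50-fold higher number (1.70 log units; beyond the scatter) from compound 3 to compound 4, 5.0-fold (0.70 log units) apart, beyond the scatter of two such steps. With a single pair on each core, this shows that the size of the step depends on the core, but not which difference between the two cores sets it.

Left open is how a group carrying an amine or a carboxylic acid would behave at this place on either core. Also open, from the compounds shown here alone, is whether the direction of the step would hold on a third core.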